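From azepan-1-yl to 4-methylpiperazin-1-yl on a thiocarbonyl carbon

This account rests on a few compounds, and the source may have more. Where it says the series, first, only, none or still open, it means among the compounds named here.

Measured in a functional assay on DU-145 cells (Homo sapiens) for inhibition, read by MTT assay, with stated times of 18 h and 4 h; on this read-out higher numbers stand for weaker inhibition and lower numbers for stronger inhibition:
Compound 1 `CCCCCCCCCCCCCCCCOP(=O)(O)OCCSC(=S)N1CCCCCC1`: 17600 nM
Compound 2 `CCCCCCCCCCOP(=O)(O)OCCSC(=S)N1CCCCCC1`: 24000 nM
Compound 3 `CCCOP(=O)(O)OCCSC(=S)N1CCCCC1`: > 100000 nM (a limit)

Among the compounds with values here, only two of the three compounds have a numerical value in this assay. Compound 2, at 24000 nM, lies within the scatter of compound 1, at 17600 nM. The remaining result belongs to compound 3, and it is a limit of the assay rather than a number.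

Compound 4 `CCCCCCCCCCOP(=O)(O)OCCSC(=S)N1CCN(C)CC1` differs from compound 2 in one place, on a thiocarbonyl carbon, where 4-methylpiperazin-1-yl stands in place of azepan-1-yl: 4-methylpiperazin-1-yl in place of azepan-1-yl on a thiocarbonyl carbon. Within the data shown here, the only measured step between compounds that differ in one place is a 1.4-fold higher number from compound 1 to compound 2 (0.13 log units; within the scatter). That step lies within the scatter, but it sits in the chain and not on the thiocarbonyl carbon. Among the measured compounds shown here, no measured step tests the new replacement directly, and the expectation therefore carries a wide range. With so little to go on, no shift beyond the scatter is expected. The expected size of the change is a 1.3-fold higher number from compound 2 to compound 4 (0.10 log units; within the scatter), an estimate that stays within the scatter. In this assay the estimate for compound 4 is 30000 nM, with the result expected between 10000 nM and 80000 nM.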

Compound 4, half-maximal inhibitory concentration: 82300 nM
Compound 4: middle estimate off by 2.7-fold (0.44 log units), on the low side; measured number outside the range, above it.
By their numbers in this assay, from the lowest: compounds 1 and 2 (each within the scatter of the next); then compound 4. At a limit, above all of these: compound 3.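

In this assay, 4-methylpiperazin-1-yl in place of azepan-1-yl on the thiocarbonyl carbon gives a 3.4-fold higher number from compound 2 to compound 4 (0.54 log units; beyond the scatter), which points to weaker inhibition and shows that this position can move the number beyond the scatter. The only earlier step, a 1.4-fold higher number from compound 1 to compound 2 (0.13 log units; within the scatter), lies in the chain and stays within the scatter, so the change on the thiocarbonyl carbon is the first one-place change shown to separate two compounds in this assay. Compound 3 is the only compound that gives a limit and not a number: the limit of > 100000 nM in this assay, at which 1 of the 4 values shown sits.

Within the data shown here, the single step changes ring size and the count of ring hetero atoms together, so it cannot show which of these goes with the weaker inhibition, and groups such as morpholin-4-yl or piperazin-1-yl without the methyl would be needed to tell them apart. On these data alone, it also remains open whether 4-methylpiperazin-1-yl would give a step of similar size on the longer chain of compound 1, or whether the step belongs only to the chain of compound 2.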